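A few compounds are considered here, and "the series" means these few. Any claim that something is new, unique, unknown or untested is made for them only; others in the source may bear on it.

Of the compounds shown here, two of a shared core have been measured. Compound 1 `COc1ccc(-c2[nH]c(-c3ccc(Cl)cc3)cc2-c2cn(-c3ccc(Cl)cc3)nc2-c2ccc(C)cc2)cc1` gives, in a functional assay on the whole organism (strain Wistar albino) for inhibition, with Rattus norvegicus as the target, read by paw edema, with stated times of 1 h and 2 h, at a dose of 0.32 mmol/kg by the intraperitoneal route (on this read-out higher numbers stand for more inhibition at the one dose given (going by the name of the read-out) and lower numbers for less inhibition), a read-out of 9.38%. Compound 2 `Cc1ccc(-c2nn(-c3ccc(S(N)(=O)=O)cc3)cc2-c2cc(-c3ccc(Cl)cc3)[nH]c2-c2ccc(F)cc2)cc1` gives in this assay a read-out of 75.4%, the higher of the two numbers and beyond the scatter from compound 1. Compound 3 `COc1ccc(-c2[nH]c(-c3ccc(Cl)cc3)cc2-c2cn(-c3ccc(S(N)(=O)=O)cc3)nc2-c2ccc(C)cc2)cc1` is not yet measured. Compound 3 differs from compound 2 in one place: methoxy in place of fluoro on an aromatic carbon, sitting on an aromatic carbon of a six-membered aromatic ring of carbon only. Within the data shown here, no step of exactly this kind stands among the measured pairs, so the direction is open. Since compound 2 keeps the rest of its structure in compound 3, the expectation is a modest fall, perhaps none beyond the scatter, with the step from a number 10.4 percentage points lower from compound 2 to compound 3 (beyond the scatter) estimated as small. Compound 3 is therefore expected to give about 65% in this assay, within a range from 40% to 85%.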

Compound 3, a percentage reported as inhibition, in the whole organism at one dose (the size of the read-out at that dose, not a potency): 49.7%
Compound 3: middle estimate off by 15.3 percentage points, on the high side; the range from low to high includes it.
By their numbers in this assay, from the lowest: compound 1; then compound 3; then compound 2.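

Compound 1 and compound 2 differ in two places, so their gap could not be assigned to either one; compound 3 now separates the two changes. In this assay, with the sulfamoyl group held constant, 4-methoxyphenyl in place of 4-fluorophenyl gives a number 25.7 percentage points lower from compound 2 to compound 3 (beyond the scatter), so the group on this aromatic carbon, para to a large group, does affect the read-out, while with the methoxy held constant, sulfamoyl in place of chloro gives a number 40.3 percentage points higher from compound 1 to compound 3 (beyond the scatter). Nothing measured here explains either step.

On these data alone, only fluoro and methoxy have been seen at this position, so it remains open how an amine, a hydroxyl or a longer chain such as ethoxy would read there. As far as these compounds go, it also remains open whether the two steps would add up in a compound carrying both fluoro and chloro.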